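Bicyclic hydroxyaryl hydrazone as a replacement for phenyl

A few compounds are considered here, and "the series" means these few. Any claim that something is new, unique, unknown or untested is made for them only; others in the source may bear on it.

Measured compounds:
Compound 1, `CN(C)CCn1cnnc1-c1cc(Oc2ccc(NC(=O)N/N=C/c3c(Cl)cccc3Cl)cc2F)ccn1`: 1410 nM
Compound 2, `CN(C)CCn1cnnc1-c1cc(Oc2ccc(NC(=O)N/N=C/c3c[nH]c4ccccc34)cc2F)ccn1`: 820 nM
Compound 3, `CN(C)CCn1cnnc1-c1cc(Oc2ccc(NC(=O)N/N=C/c3ccccc3)cc2F)ccn1`: 1860 nM

In a functional assay on A549 cells (Homo sapiens) for cytotoxicity, read by MTT assay, with a stated time of 72 h (a lower number here means a stronger inhibitor, a higher number a weaker inhibitor), compound 3 gives 1860 nM, the top of the three numbers: it lies beyond the scatter above compound 2, as a 2.3-fold higher number from compound 2 to compound 3 (0.36 log units; beyond the scatter), whereas its separation from compound 1, a 1.3-fold higher number from compound 1 to compound 3 (0.12 log units; within the scatter), is within the scatter. Compound 4, `CN(C)CCn1cnnc1-c1cc(Oc2ccc(NC(=O)N/N=C/c3c(O)ccc4ccccc34)cc2F)ccn1`, differs from compound 3 in one place: 2-hydroxynaphthalen-1-yl in place of phenyl on a carbon with a double bond to nitrogen. The step that bears most directly on this change is a 2.3-fold higher number from compound 2 to compound 3 (0.36 log units; beyond the scatter), where a bicyclic aromatic group on the same carbon went with a lower number than phenyl. The step of a 1.3-fold higher number from compound 1 to compound 3 (0.12 log units; within the scatter) shows that substitution on the phenyl alone left the number within the scatter. Among the measured compounds shown here, no measured step covers a hydroxyl at this position, so the effect of that group is unknown. On this basis compound 4 is expected to give a number somewhat below that of compound 3, an estimated step of a 1.9-fold lower number from compound 3 to compound 4 (0.27 log units; within the scatter), with wide uncertainty. Compound 4 is therefore estimated at 1000 nM in this assay, within a range from 400 nM to 2500 nM.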

Compound 4, half-maximal inhibitory concentration: 880 nM
Beside the measured number, compound 4's estimate is 1.1-fold (0.06 log units) above it; measured number inside the range.
By their numbers in this assay, from the lowest: compounds 2, 4, 1 and 3 (each within the scatter of the next, the first and the last beyond it).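

In this assay the 2-hydroxynaphthalen-1-yl group on this carbon stands apart from phenyl beyond the scatter (a 2.1-fold lower number from compound 3 to compound 4 (0.33 log units; beyond the scatter)), so a second bicyclic aromatic group, after the 1H-indol-3-yl of compound 2, goes with a lower number than phenyl. Compound 4 cannot be told apart from compound 2 (a 1.1-fold higher number from compound 2 to compound 4 (0.03 log units; within the scatter)) or from compound 1 (a 1.6-fold lower number from compound 1 to compound 4 (0.20 log units; within the scatter)), and compound 1, with its single ring, goes against any clean split by ring count, as it lies within the scatter of all three other compounds. No measurement shown here accounts for the step.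

The compounds shown leave open whether the hydroxyl or the second ring goes with the lower number, a question that a plain naphthalen-1-yl group would address. As far as these compounds go, how a methoxy group or an amine in place of the hydroxyl would read also remains open.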